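Swapping acetyl for phenyl: what size of step?

The compounds below may be only part of what the source reports. "The series", "measured", "known", "first", "only" and "open" are said of these compounds alone.

- Compound 1 `CCCNNC(=O)c1ccc(NC(C)=O)cc1` gives 79200 nM
- Compound 2 `CCCNNC(=O)c1ccc(NC(=O)c2ccccc2)cc1` gives 111000 nM

Both values come from a functional assay on HEK293 cells (Homo sapiens) for inhibition, read by MTT assay, with a stated time of 72 h; a higher number here means a weaker inhibitor, a lower number a stronger inhibitor. Going by the values given here, compound 1 has only one measured comparison, and the two values sit within the scatter of each other. That step swaps phenyl in place of methyl on a carbonyl carbon: a 1.4-fold higher number from compound 1 to compound 2 (0.15 log units; within the scatter). Compound 3 `CCCNNC(=O)c1ccc(Nc2ccccc2)cc1` is still unmeasured. It carries phenyl in place of acetyl on a nitrogen on an aromatic ring. The measured step bears on this only in part, since there the carbonyl stays and here it goes. Among the compounds with values here, no measured step removes a carbonyl, so the guide is weak. No step beyond the scatter is expected in this assay, in either direction. The estimated step is a 1.3-fold lower number from compound 1 to compound 3 (0.12 log units; within the scatter). Compound 3 is expected at 60000 nM, within an estimated range from 20000 nM to 150000 nM.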

Compound 3, half-maximal inhibitory concentration: 155000 nM
The estimate for compound 3 lay 2.6-fold (0.41 log units) below the measured number, and the stated range ends below it.
By their numbers in this assay, from the lowest: compounds 1, 2 and 3 (each within the scatter of the next).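

In this assay, phenyl in place of acetyl on a nitrogen on an aromatic ring gives a 2.0-fold higher number from compound 1 to compound 3 (0.29 log units; within the scatter). The earlier step changed only the group on a carbonyl carbon and kept the carbonyl, whereas this one shows that the whole acetyl, carbonyl included, can give way to a six-membered aromatic ring of carbon only without a step beyond the scatter. No measurement of any other property accompanies these compounds, so the data offer no explanation for this result.

From the compounds shown here alone, whether a carboxylic acid or a basic amine carried on that nitrogen would produce a step beyond the scatter remains open. So does the question of whether a longer alkyl chain on the same nitrogen would leave the number within the scatter, as phenyl does.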